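From Benzamido to Acetamido on a Shared Core

The compounds below may be only part of what the source reports. "The series", "measured", "known", "first", "only" and "open" are said of these compounds alone.

In a functional assay on HUVEC cells (Homo sapiens) for inhibition (a higher number here means a weaker inhibitor, a lower number a stronger inhibitor), compound 3 `COc1cc(/C=C/C(=O)c2cccc(NC(=O)c3ccccc3)c2)ccc1O` gives 0.37 ug/mL. Compound 1 `COc1cc(/C=C/C(=O)c2cccc(NC(=O)c3ccco3)c2)ccc1O` gives 0.38 ug/mL, and the two sit together, with a 1.0-fold lower number from compound 1 to compound 3 (0.01 log units; within the scatter). Compound 2 `COc1cc(/C=C/C(=O)c2cccc(NC(=O)c3ccc(Cl)c(Cl)c3)c2)ccc1O` stands apart at 2.97 ug/mL, with an 8.0-fold lower number from compound 2 to compound 3 (0.90 log units; beyond the scatter).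

Compound 4 `COc1cc(/C=C/C(=O)c2cccc(NC(C)=O)c2)ccc1O` carries methyl in place of phenyl on a carbonyl carbon. Two measured changes at this place bear on it, a 1.0-fold lower number from compound 1 to compound 3 (0.01 log units; within the scatter) and a 7.8-fold higher number from compound 1 to compound 2 (0.89 log units; beyond the scatter). Every measured compound keeps a ring there, so the guide is loose. A modest rise is expected, and the expected step is a 2.2-fold higher number from compound 3 to compound 4 (0.33 log units; beyond the scatter). Compound 4 is estimated at 0.8 ug/mL, within an expected range of 0.2 ug/mL to 4 ug/mL.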

Compound 4, half-maximal inhibitory concentration: 7.06 ug/mL
The estimate for compound 4 lay 8.8-fold (0.95 log units) below the measured number; measured number above the stated range.
By their numbers in this assay, from the lowest: compounds 3 and 1 (each within the scatter of the next); then compound 2; then compound 4.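

Replacing the ring on this carbonyl carbon with methyl matters far more than exchanging phenyl for furan-2-yl: in this assay there is a 19-fold higher number from compound 3 to compound 4 (1.28 log units; beyond the scatter) and a 19-fold higher number from compound 1 to compound 4 (1.27 log units; beyond the scatter) in the same direction. Even the 3,4-dichlorophenyl amide keeps a lower number than the acetamido compound, with a 2.4-fold higher number from compound 2 to compound 4 (0.38 log units; beyond the scatter), so all three ring-bearing amides shown stand below methyl. No measurement shown accounts for this difference.

Going by these compounds, whether a longer chain such as propyl, or a saturated ring such as cyclohexyl, would restore the lower numbers remains open. The compounds shown therefore cannot separate the aromatic ring from the mere bulk of the group.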